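The compounds below may be only part of what the source reports. "The series", "measured", "known", "first", "only" and "open" are said of these compounds alone.

Measured so far:
- compound 1 `O=C1COC(c2ccc(/N=C/c3cccc(Cl)c3)cc2)=NN1`: in an assay on cells for inhibition of Amine oxidase [flavin-containing] B (Homo sapiens), read by Amplex Red, with a stated time of 30 min (a higher number here means a weaker inhibitor, a lower number a stronger inhibitor), compound 1 gives 257 nM
- compound 2 `Cc1cccc(/C=N/c2ccc(C3=NNC(=O)CO3)cc2)c1`: in this assay compound 2 gives 1270 nM

Compound 1 has the lowest number of the two; its nearest neighbour is compound 2, and the step of a 4.9-fold higher number from compound 1 to compound 2 (0.69 log units; beyond the scatter) lies beyond the scatter. Compound 3 `CN1N=C(c2ccc(/N=C/c3cccc(Cl)c3)cc2)OCC1=O` has not been measured yet. It differs from compound 1 by methyl in place of hydrogen on an amide-type nitrogen in a ring, a single carbon added on the shared core, leaving the rest of the molecule untouched.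

For the measured compounds named here, no measured step bears on this change: the only step available, from compound 1 to compound 2, concerns the group on the outer aromatic ring, a different part of the molecule. The effect of capping the ring nitrogen therefore has to be guessed from the structures alone, and the guess is uncertain. A small change of this kind is expected to move the number by a modest amount, most likely upward, so compound 3 is expected to give a step of a 2.7-fold higher number from compound 1 to compound 3 (0.44 log units; beyond the scatter) in this assay. Compound 3 is thus estimated at 700 nM, within a range from 150 nM to 3500 nM.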

Compound 3, half-maximal inhibitory concentration: 2030 nM
Beside the measured number, compound 3's estimate is 2.9-fold (0.46 log units) below it; the measured number falls inside the stated range.
By their numbers in this assay, from the lowest: compound 1; then compounds 2 and 3 (each within the scatter of the next).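

In this assay, methyl in place of hydrogen on the amide-type nitrogen in the ring gives a 7.9-fold higher number from compound 1 to compound 3 (0.90 log units; beyond the scatter) and is the first change shown on the shared core, since the step from compound 1 to compound 2 concerned only the group on the outer aromatic ring. The result shows that this nitrogen is not a place where a change passes unnoticed: a single added carbon, with the rest of the molecule untouched, moves the number beyond the scatter. Among the compounds shown, the free amide hydrogen goes with the lower number, though this rests on one pair only.

Going by these compounds, what stays open is whether the amide hydrogen itself matters or the added carbon does, as one methyl group changes both at once. An ethyl group or a longer chain on the same nitrogen would show how the number follows the size of the group there, and a hydroxyethyl group or an amine at the end of such a chain would test other kinds of group. No measurement available here gives a reason for this step.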